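Trifluoromethoxy for Trifluoromethyl on the Sulfonyl Aryl Ring

The compounds below may be only part of what the source reports. "The series", "measured", "known", "first", "only" and "open" are said of these compounds alone.

Three compounds have been measured in a functional assay on LNCaP cells (Homo sapiens) for antiproliferative activity, read by fluorescence and propidium iodide staining, with a stated time of 96 h; on this read-out lower numbers stand for stronger inhibition and higher numbers for weaker inhibition:
Compound 1 `CC(O)(CSc1cc(C(F)(F)F)cc(C(F)(F)F)c1)C(=O)Nc1ccc([N+](=O)[O-])cc1C(F)(F)F` gives 3110 nM.
Compound 2 `CC(O)(CSc1cc(C(F)(F)F)cc(C(F)(F)F)c1)C(=O)Nc1ccc(C(F)(F)F)cc1` gives 9610 nM.
Compound 3 `CC(O)(CS(=O)(=O)c1ccccc1C(F)(F)F)C(=O)Nc1cc(C(F)(F)F)cc(C(F)(F)F)c1` gives 8510 nM.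

Compound 3 holds the second highest of these numbers in this assay. Its nearest neighbour is compound 2, whose value differs from it by an amount within the scatter, so no order between compound 2 and compound 3 can be claimed. Compound 1, the furthest away, gives the lowest number of the set, and its gap from compound 3 lies beyond the scatter.

Compound 4 `CC(O)(CS(=O)(=O)c1ccccc1OC(F)(F)F)C(=O)Nc1cc(C(F)(F)F)cc(C(F)(F)F)c1` has not yet been measured. It differs from compound 3 in one place: trifluoromethoxy in place of trifluoromethyl on an aromatic carbon. The group that enters carries one hydrogen-bond acceptor where the group that leaves carried none, and it sits ortho to a large group on the six-membered aromatic ring of carbon only.

Within the data shown here, no step between two measured compounds tells how this change acts in this assay. The expected step of a 1.1-fold lower number from compound 3 to compound 4 (0.03 log units; within the scatter) is therefore small, with no direction claimed beyond the scatter. Compound 4 is estimated at 8000 nM in this assay, with a range from 3000 nM to 20000 nM.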

Compound 4, half-maximal inhibitory concentration: 8020 nM
For compound 4 the middle estimate is 1.0-fold (0.00 log units) below the measured one; the range from low to high includes it.
By their numbers in this assay, from the lowest: compound 1; then compounds 4, 3 and 2 (each within the scatter of the next).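

Trifluoromethoxy in place of trifluoromethyl on an aromatic carbon, ortho to a large group, gives a 1.1-fold lower number from compound 3 to compound 4 (0.03 log units; within the scatter) in this assay and is the first step in the set between two compounds that differ in one place. On this read-out, the two groups cannot be told apart at this position, even though the entering group adds an oxygen and carries a hydrogen-bond acceptor that the leaving group lacked, and no order between compound 3 and compound 4 can be claimed. Nothing at hand explains why the two groups read alike here.

The compounds shown leave open how this position responds to a group of a different kind, such as an amine, a carboxylic acid or a simple methyl, since trifluoromethyl and trifluoromethoxy are the only two groups seen on it so far. They also leave open whether the same exchange would read alike on the core of compound 1 or compound 2, where a thioether stands in place of the sulfonyl, and no pair shown changes that link alone.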